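The compounds below may be only part of what the source reports. "The series", "measured", "known", "first", "only" and "open" are said of these compounds alone.

Measured compounds: compound 1 `CC(C)(C)c1ccc(NC(=O)c2ccc(-c3ncccc3F)cc2)cc1` with 1 nM; compound 2 `CC(C)(C)c1ccc(NC(=O)c2ccc(-c3ncccc3NS(=O)(=O)c3ccccc3)cc2)cc1` with 166 nM.

Within the data shown here, in a functional assay for antagonist activity at transient receptor potential cation channel subfamily V member 1 (Rattus norvegicus) (a higher number here means a weaker inhibitor, a lower number a stronger inhibitor), compound 2 holds the higher of the two numbers, the only recorded step being a 170-fold higher number from compound 1 to compound 2 (2.22 log units; beyond the scatter), which came with (phenylsulfonyl)amino in place of fluoro. Compound 3 `CC(C)(C)c1ccc(NC(=O)c2ccc(-c3ncccc3C(=N)N)cc2)cc1` differs from compound 2 by a group of 3 heavy atoms (1 carbon, 2 nitrogen; no ring) in place of a group of 10 heavy atoms (6 carbon, 1 nitrogen, 2 oxygen, 1 sulfur; one six-membered aromatic ring of carbon only), on an aromatic carbon, on the carbon two atoms from the ring nitrogen. Among the measured compounds shown here, no measured step covers this exact exchange, but the large rise seen in a 170-fold higher number from compound 1 to compound 2 (2.22 log units; beyond the scatter) when the (phenylsulfonyl)amino group entered suggests that its departure should bring the number back down, so compound 3 is expected to show a 5.5-fold lower number from compound 2 to compound 3 (0.74 log units; beyond the scatter). Compound 3 is therefore estimated at 30 nM, within 5 nM to 300 nM.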

Compound 3, half-maximal inhibitory concentration: > 4000 nM
Compound 3: only a limit was reported; the forecaster's own chance of this, stated with the estimate: 5%; middle value at least 130-fold (2.12 log units) from the limit.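

In this assay compound 3 gives > 4000 nM, which is a limit and not a number. Losing the (phenylsulfonyl)amino group did not bring the number down, as the change gave an at least 24-fold higher number from compound 2 to compound 3 (1.38 log units; beyond the scatter). Measured against fluoro, the same group of 3 heavy atoms gave an at least 4000-fold higher number from compound 1 to compound 3 (3.60 log units; beyond the scatter), so at this position, two atoms from the ring nitrogen, the number does not follow the count of heavy atoms. From the compounds shown here alone, what remains open is whether an amine or a methyl group here would stay close to compound 1 or fall towards compound 3. Going by these compounds, how far compound 3 lies beyond its limit also stays unknown.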